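The source may report more compounds than this note shows. Statements on the series, on what has been measured and on what is new or still open speak of the compounds shown alone.

Three compounds have been measured in an assay on CHO cells for displacement of a labelled ligand from 5-hydroxytryptamine receptor 1D (Homo sapiens); a lower number here means a stronger inhibitor, a higher number a weaker inhibitor:
Compound 1, `O=S(=O)(NCC1CCN(CCCc2c[nH]c3ccc(-n4cnnc4)cc23)CC1)c1ccccc1`, gives 6.2 nM.
Compound 2, `c1cncc(CNC2CCN(CCCc3c[nH]c4ccc(-n5cnnc5)cc34)CC2)c1`, gives 35 nM.
Compound 3, `CC(=O)Nc1ccc(CNCC2CCN(CCCc3c[nH]c4ccc(-n5cnnc5)cc34)CC2)cc1`, gives 4.2 nM.

Compound 1 thus holds the second highest of the three numbers: compound 3 sits nearest, a 1.5-fold lower number from compound 1 to compound 3 (0.17 log units; within the scatter), while compound 2 is furthest, a 5.6-fold higher number from compound 1 to compound 2 (0.75 log units; beyond the scatter). Compound 4, `c1ccc2c(c1)CCC2NCC1CCN(CCCc2c[nH]c3ccc(-n4cnnc4)cc23)CC1`, has not yet been measured. It differs from compound 1 in one place: 2,3-dihydro-1H-inden-1-yl in place of phenylsulfonyl on an amine nitrogen. The step from compound 1 to compound 3 is the closest guide, as it also replaced the phenylsulfonyl on that same amine nitrogen with another group, and it stayed within the scatter. Among the measured compounds shown here, only that one comparable step is known, and the step from compound 1 to compound 2, a different kind of change, was larger. On this basis compound 4 is expected to give about 10 nM, between 3.5 nM and 30 nM, meaning a 1.6-fold higher number from compound 1 to compound 4 (0.21 log units; within the scatter).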

Compound 4, half-maximal inhibitory concentration: 1.1 nM
Estimate against measurement, compound 4: 9.1-fold (0.96 log units) above; measured number below the stated range.
By their numbers in this assay, from the lowest: compound 4; then compounds 3 and 1 (each within the scatter of the next); then compound 2.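

In this assay, this amine nitrogen does not need the sulfonyl group: the all-carbon 2,3-dihydro-1H-inden-1-yl gives a 5.6-fold lower number from compound 1 to compound 4 (0.75 log units; beyond the scatter) when it replaces phenylsulfonyl, so a change here can do more than stay within the scatter. The same group also gives a 3.8-fold lower number from compound 3 to compound 4 (0.58 log units; beyond the scatter) in place of 4-acetamidobenzyl, and a 32-fold lower number from compound 2 to compound 4 (1.50 log units; beyond the scatter) as part of the larger change on the saturated ring carbon. Nothing available accounts for these differences.

Still open, going by these compounds, is whether the five-membered non-aromatic ring matters, or whether a plain benzyl or a cyclohexyl group on that nitrogen would give a similar number.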